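Ethyl in Place of Methyl: Compound 4 Awaited

The source may hold more compounds than are shown below. What is called first, only, known or untested is meant among the compounds shown, and "the series" means these compounds.

Compound 1, `CCn1c(/C=C2\SC(=O)N(CC(=O)N3CCCCC3)C2=O)nc2ccccc21`: > 50000 nM in a functional assay on A549 cells (Homo sapiens) for inhibition, read by MTT assay, with a stated time of 48 h (on this read-out higher numbers stand for weaker inhibition and lower numbers for stronger inhibition), a limit of the assay.
Compound 2, `Cn1c(/C=C2\SC(=O)N(CC(=O)N3CCCCC3)C2=O)nc2ccccc21`: > 50000 nM in this assay, a limit of the assay.
Compound 3, `Cn1c(/C=C2\SC(=O)N(CC(=O)Nc3nc(-c4ccccc4)cs3)C2=O)nc2ccccc21`: 11500 nM in this assay.

Compound 2 and compound 1 share the same acyl piperidine part and differ only by methyl in place of hydrogen on a saturated chain carbon bound to an aromatic nitrogen. Both sit at the limit of this assay, so the step that the two limits leave unreadable from compound 2 to compound 1 cannot be read, a consequence of the limit of > 50000 nM in this assay, at which 2 of the 3 values shown sit. For the measured compounds named here, compound 3 carries a different amide part and is the only compound with a number in this assay; how its core differs from that of compound 2 is not broken down here.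

Compound 4, `CCn1c(/C=C2\SC(=O)N(CC(=O)Nc3nc(-c4ccccc4)cs3)C2=O)nc2ccccc21`, is not yet measured. It differs from compound 3 by methyl in place of hydrogen on a saturated chain carbon bound to an aromatic nitrogen, the same change that turns compound 2 into compound 1, made in the same place. Because the step that the two limits leave unreadable from compound 2 to compound 1 is unreadable, the measured pair gives no size for this change. The step from compound 3 to compound 4 is therefore expected to be small, a 1.0-fold higher number from compound 3 to compound 4 (0.02 log units; within the scatter), within the usual scatter. Going by the values given here, compound 4 is estimated at 12000 nM in this assay, between 4000 nM and 40000 nM, resting on the value of compound 3, 11500 nM, as the only number available.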

Compound 4, half-maximal inhibitory concentration: > 50000 nM
Compound 4 was reported as a limit; the forecaster's own chance of this, stated with the estimate: 20%; middle value at least 4.1-fold (0.61 log units) away from the limit.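

On the amide part of compound 3, methyl in place of hydrogen on a saturated chain carbon bound to an aromatic nitrogen, which turns 1-methyl-1H-benzimidazol-2-yl into 1-ethyl-1H-benzimidazol-2-yl, gives an at least 4.3-fold higher number from compound 3 to compound 4 (0.63 log units; beyond the scatter) in this assay, so this change costs inhibition on that amide part. The same change on the acyl piperidine part, from compound 2 to compound 1, cannot be read, and the series therefore offers no second size to set beside the new one, so it does not show whether the effect carries from one core to another: the limit of > 50000 nM in this assay, at which 3 of the 4 values shown sit. The new step gives only a lower bound on the size of the change on a single core, and one pair with a readable direction establishes no rule for the series.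

The compounds shown leave open whether a longer chain such as propyl, or a chain ending in an amine or a carboxylic acid, on the same aromatic nitrogen would lower or raise the number set by compound 3. They also leave open whether hydrogen in place of the methyl of compound 3 would move that number at all.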